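Replacing the trifluoromethoxy group of compound 3

The source may hold more compounds than are shown below. What is called first, only, known or untested is meant among the compounds shown, and "the series" means these compounds.

Compound 1 `O=C(C[C@]1(O)CC[C@@H](Cc2ccccc2)CC1)Nc1ccc2[nH]c(=O)oc2c1` gives 47.4%
Compound 2 `O=C(C[C@]1(O)CC[C@@H](Cc2ccc(F)cc2)CC1)Nc1ccc2[nH]c(=O)oc2c1` gives 42.4%
Compound 3 `O=C(C[C@]1(O)CC[C@@H](Cc2ccc(OC(F)(F)F)cc2)CC1)Nc1ccc2[nH]c(=O)oc2c1` gives 53.4%

These three values come from an ADME assay on the whole organism (strain Sprague-Dawley) for pharmacokinetics, with Rattus norvegicus as the target, using cassette dosing, at a dose of 1 mg/kg by the oral route; a higher number here means that a larger share of the oral dose reaches the circulation, a lower number that a smaller share of the oral dose reaches the circulation. Compound 3 sits close to one of its two relatives and further from the other. The data show a number 6 percentage points higher from compound 1 to compound 3 (within the scatter), and they also show a number 11 percentage points higher from compound 2 to compound 3 (beyond the scatter).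

The next compound to be tested is compound 4 `O=C(C[C@]1(O)CC[C@@H](Cc2ccc(F)c(F)c2)CC1)Nc1ccc2[nH]c(=O)oc2c1`. Its difference from compound 3 is 3,4-difluorophenyl in place of 4-(trifluoromethoxy)phenyl on a saturated chain carbon bound to a saturated ring carbon. In words, this is 3,4-difluorophenyl in place of 4-(trifluoromethoxy)phenyl on a saturated chain carbon bound to a saturated ring carbon. Within the data shown here, no measured compound carries this new group, so only two steps offer guidance. The nearer one is a number 11 percentage points higher from compound 2 to compound 3 (beyond the scatter), which, read in reverse, points to a loss on leaving the trifluoromethoxy group for fluoro. The other is a number 5 percentage points lower from compound 1 to compound 2 (within the scatter), the only measured case of fluoro in place of hydrogen, and it stays within the scatter. Together they suggest a lower number in this assay, though the drop may not clear the scatter. The expected change is a number 9.4 percentage points lower from compound 3 to compound 4 (within the scatter). For compound 4 the estimate is 44%, with an expected range from 30% to 58%.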

Compound 4, oral bioavailability: 12.1%
The estimate for compound 4 lay 31.9 percentage points above the measured number; measured number outside the range, below it.
By their numbers in this assay, from the lowest: compound 4; then compounds 2, 1 and 3 (each within the scatter of the next, the first and the last beyond it).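

In this assay the extra fluoro of the 3,4-difluorophenyl group has a far larger effect than the first, with a number 30.3 percentage points lower from compound 2 to compound 4 (beyond the scatter) set against a number 5 percentage points lower from compound 1 to compound 2 (within the scatter) for the earlier replacement, so fluoro in place of hydrogen on an aromatic carbon of this ring does not carry one fixed effect. Among these compounds, the 3,4-difluorophenyl group also stands well apart from the two other groups at this place on a saturated chain carbon bound to a saturated ring carbon, with a number 35.3 percentage points lower from compound 1 to compound 4 (beyond the scatter) from the unsubstituted phenyl and a number 41.3 percentage points lower from compound 3 to compound 4 (beyond the scatter) from the 4-(trifluoromethoxy)phenyl group, so the earlier compounds, which spanned a much narrower band, gave no sign of so steep a loss. Nothing available offers a reason for this drop.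

The compounds shown leave open whether the loss belongs to the two fluoro groups as such or would recur with a 3,4-dichlorophenyl group. They also leave open whether a single methoxy or chloro group added to the phenyl ring at this place would keep the oral share of compound 1 or lose it as compound 4 does.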